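Working notes: methyl on the sulfonyl phenyl, compound 3 to 4

The compounds below may be only part of what the source reports. "The series", "measured", "known", "first", "only" and "open" are said of these compounds alone.

Values in an assay on Sf9 cells for inhibition of mitogen-activated protein kinase kinase kinase 20 (Homo sapiens), read by ADP-Glo, with a stated time of 30 min (a lower number here means a stronger inhibitor, a higher number a weaker inhibitor), so far:
compound 1 `COc1n[nH]c2ncc(-c3cn(-c4cccc(NS(=O)(=O)c5cccc(Cl)c5)c4)nn3)cc12` gives 24.7 nM
compound 2 `COc1n[nH]c2ncc(-c3cn(-c4c(Cl)ccc(NS(=O)(=O)c5cccc(Cl)c5)c4Cl)nn3)cc12` gives 413 nM
compound 3 `COc1n[nH]c2ncc(-c3cn(-c4c(F)ccc(NS(=O)(=O)c5ccccc5)c4F)nn3)cc12` gives 3.8 nM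

Compound 3 holds the lowest number of the three. Its nearest neighbour is compound 1, whose number is higher by more than the scatter; compound 2 lies furthest away, also beyond the scatter. Compound 4 `COc1n[nH]c2ncc(-c3cn(-c4c(F)ccc(NS(=O)(=O)c5cccc(C)c5)c4F)nn3)cc12` is the next member. It differs from compound 3 by methyl in place of hydrogen on an aromatic carbon, a methyl in place of hydrogen on an aromatic carbon of the phenylsulfonyl group. Within the data shown here, no pair among the measured compounds shows this change, so there is nothing to calibrate it against. The expected step in this assay from compound 3 to compound 4 is a 1.2-fold higher number from compound 3 to compound 4 (0.07 log units; within the scatter), small and in no clear direction, likely within the scatter. Compound 4 is therefore estimated at 4.5 nM, with a range of 1.5 nM to 14 nM.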

Compound 4, half-maximal inhibitory concentration: 4.4 nM
Compound 4: middle estimate off by 1.0-fold (0.01 log units), on the high side; the measured number falls inside the stated range.
By their numbers in this assay, from the lowest: compounds 3 and 4 (each within the scatter of the next); then compound 1; then compound 2.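

In this assay a methyl in place of hydrogen on an aromatic carbon of the phenylsulfonyl group gives a 1.2-fold higher number from compound 3 to compound 4 (0.06 log units; within the scatter) and thus no change that can be told from the scatter. Among these compounds, this is the first comparison that differs in one place, and it shows that the 3-methylphenyl group keeps the number of the phenyl compound within the scatter. Nothing measured here speaks to the reason for this result. Open, on these data alone, is whether a longer chain such as propyl, an amine or a carboxylic acid on the same carbon would leave the number equally undisturbed.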